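This account rests on a few compounds, and the source may have more. Where it says the series, first, only, none or still open, it means among the compounds named here.

Compounds measured in an ADME assay on L02 cells (Homo sapiens) for cytotoxicity, read by MTT assay; a higher number here means a weaker inhibitor, a lower number a stronger inhibitor:
- compound 1 `COc1ccc(Nc2nc(/C=C/c3cc(OC)c(OC)c(OC)c3)nc3ccsc23)cc1`: 279000 nM
- compound 2 `COc1cc(/C=C/c2nc(NCc3ccc(C)cc3)c3sccc3n2)cc(OC)c1OC`: 2930000 nM

Compound 2 holds the highest of the two numbers in this assay; its nearest neighbour is compound 1, reached by the step of an 11-fold higher number from compound 1 to compound 2 (1.02 log units; beyond the scatter). Compound 3 `COc1cc(/C=C/c2nc(NCc3ccncc3)c3sccc3n2)cc(OC)c1OC` is not yet measured in this assay. It differs from compound 2 by pyridin-4-yl in place of 4-methylphenyl on a saturated chain carbon bound to a nitrogen on an aromatic ring. Among the compounds with values here, the only measured step, from compound 1 to compound 2, also alters the group on the nitrogen on the aromatic ring, and it was large; it does not, however, replace an aryl ring by a pyridinyl ring on the saturated chain carbon, so it offers no direct precedent. No change beyond the scatter is expected in this assay for compound 3, with an expected step of a 1.2-fold lower number from compound 2 to compound 3 (0.07 log units; within the scatter). For compound 3 the estimated value in this assay is 2500000 nM, within a range from 800000 nM to 8000000 nM.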

Compound 3, half-maximal inhibitory concentration: 374000 nM
Estimate against measurement, compound 3: 6.7-fold (0.83 log units) above; measured number outside the range, below it.
By their numbers in this assay, from the lowest: compounds 1 and 3 (each within the scatter of the next); then compound 2.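

In this assay, the ring on the saturated chain carbon bound to a nitrogen on an aromatic ring matters with the chain kept in place: pyridin-4-yl in place of 4-methylphenyl gives a 7.8-fold lower number from compound 2 to compound 3 (0.89 log units; beyond the scatter). Replacing 4-methoxyphenyl on the nitrogen with (pyridin-4-yl)methyl gives only a 1.3-fold higher number from compound 1 to compound 3 (0.13 log units; within the scatter), so the chain carbon alone does not go with the high number seen for compound 2. No evidence on the cause of either step is at hand.

From the compounds shown here alone, whether the drop follows the ring nitrogen or the loss of the methyl stays open, and an unsubstituted benzyl on the same nitrogen would separate the two. Also open, going by these compounds, is whether pyridin-3-yl or a longer chain carrying pyridin-4-yl would read like compound 3.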